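From propyl to butyl on compound 2

The source may report more compounds than this note shows. Statements on the series, on what has been measured and on what is new or still open speak of the compounds shown alone.

In a functional assay on the whole organism (strain Sprague-Dawley) for inhibition, with Rattus norvegicus as the target, with a stated time of 10 min (on this read-out higher numbers stand for an effect only at larger amounts of compound and lower numbers for an effect already at smaller amounts), compound 1 `O=C(O)c1cnc(-c2ccccc2[N+](=O)[O-])[nH]c1=O` reads > 50 mg/kg, which is a limit and not a number. For the measured compounds named here, compound 2 `CCCOc1ccccc1-c1ncc(C(=O)O)c(=O)[nH]1` gives 0.9 mg/kg, the only true number so far. Placing propoxy where nitro stood produced an at least 55-fold lower number from compound 1 to compound 2 (1.74 log units; beyond the scatter), a large step. Compound 3 `CCCCOc1ccccc1-c1ncc(C(=O)O)c(=O)[nH]1` lengthens propyl to butyl: methyl in place of hydrogen on a saturated chain carbon, three bonds along the chain from an oxygen on an aromatic ring. That measured step exchanged one group for a quite different one, so it offers only weak guidance for this smaller change. The expected result is a 1.7-fold higher number from compound 2 to compound 3 (0.22 log units; within the scatter), not beyond the usual scatter. Compound 3 is estimated at 1.5 mg/kg, within a range of 0.4 mg/kg to 6 mg/kg.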

Compound 3, dose for 50% inhibition: 0.5 mg/kg
Compound 3: the middle estimate sits 3.0-fold (0.48 log units) above what was measured; low and high end bracket the measured number.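

Adding one carbon to the chain gives a 1.8-fold lower number from compound 2 to compound 3 (0.26 log units; within the scatter), so in this assay propoxy and butoxy cannot be told apart, and the added methyl leaves the dose in the same range. Butoxy in place of nitro gives an at least 100-fold lower number from compound 1 to compound 3 (2.00 log units; beyond the scatter), so a second alkoxy chain also stands far from nitro. Compound 1 carries a limit and not a number: the limit of > 50 mg/kg in this assay, at which 1 of the 3 values shown sits.

As far as these compounds go, whether a longer chain, such as pentyl, holds this level stays open. So does the effect of an amine on the chain.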